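The compounds below may be only part of what the source reports. "The series", "measured", "known", "first", "only" and "open" are said of these compounds alone.

Measured compounds:
compound 1 `C=COC(=O)CCCCCCCCCCC(=O)OC[C@H]1Oc2ccc([C@H]3Oc4cc(O)cc(O)c4C(=O)[C@@H]3O)cc2O[C@@H]1c1ccc(O)c(OC)c1` — 372000 nM
compound 2 `COc1cc([C@H]2Oc3cc([C@H]4Oc5cc(O)cc(O)c5C(=O)[C@@H]4O)ccc3O[C@@H]2COC(=O)CCCCCCCCCCC(=O)OCC2(C)CCc3c(C)c(O)c(C)c(C)c3O2)ccc1O` — 3500 nM

Two compounds have been run in a functional assay, read by spectrophotometry, with a stated time of 30 min; a lower number here means a stronger inhibitor, a higher number a weaker inhibitor. Compound 1 gives 372000 nM, the highest of the two numbers; compound 2 gives 3500 nM, a much lower number, and the gap lies well beyond the scatter. Among the compounds with values here, no step is drawn for that pair, since the two esters differ in more than one place, so the two values may only be set side by side.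

Compound 3 `COc1cc([C@H]2Oc3cc([C@H]4Oc5cc(O)cc(O)c5C(=O)[C@@H]4O)ccc3O[C@@H]2COC(=O)CCCCCCCCCCC(=O)OCCc2ccc(O)cc2)ccc1O` has not yet been measured. It derives from compound 1 by one change: 2-(4-hydroxyphenyl)ethyl in place of vinyl on an oxygen next to a carbonyl group. Compound 1 carries the smallest ester group of the set and gives the weakest inhibition, while compound 2, with a far larger ester group, gives the strongest. Compound 3 sits, in size of that group, closer to compound 2 than to compound 1, and the change brings in a phenol not present in compound 1. On this basis compound 3 is expected to give a clearly lower number than compound 1. That expectation means a step of a 9.3-fold lower number from compound 1 to compound 3 (0.97 log units; beyond the scatter), judged to fall beyond the scatter. Compound 3 is therefore estimated at 40000 nM, with a range from 8000 nM to 200000 nM.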

Compound 3, half-maximal inhibitory concentration: 253000 nM
For compound 3 the middle estimate is 6.3-fold (0.80 log units) below the measured one; the measured number lies above the stated range.
By their numbers in this assay, from the lowest: compound 2; then compounds 3 and 1 (each within the scatter of the next).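

In this assay, 2-(4-hydroxyphenyl)ethyl in place of vinyl on an oxygen next to a carbonyl group gives a 1.5-fold lower number from compound 1 to compound 3 (0.17 log units; within the scatter), so at this position the exchange leaves the number within the scatter. Within the data shown here, the exchange brings in a six-membered aromatic ring and a hydrogen-bond donor and removes the double bond of the vinyl group, yet these differences together produce no step that can be told apart from repeated measurement, so a larger ester group at this position does not by itself go with a clearly lower number. Nothing measured here offers an explanation for this result.

Compound 3 gives 253000 nM and compound 2 gives 3500 nM in this assay, and the compounds shown leave open which feature of the ester group of compound 2 goes with its value, whether its fused ring system, its phenol or its methyl groups. They also leave open how this position would respond to a plain carboxylic acid or an amine at the end of the chain, and whether a longer chain between the two ester carbonyl groups would change the number.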